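A few compounds are considered here, and "the series" means these few. Any claim that something is new, unique, unknown or untested is made for them only; others in the source may bear on it.

Compound 1, `Ic1nc2ccccc2[se]1`, in a functional assay on NCI-H522 cells (Homo sapiens) for cytotoxicity, with a stated time of 3 days (on this read-out higher numbers stand for weaker inhibition and lower numbers for stronger inhibition), gives > 40000 nM, which is a limit of the assay and not a number.
Compound 2, `c1ccc2[se]cnc2c1`, in this assay gives > 40000 nM, again a limit of the assay rather than a number.
Compound 3, `C#CCNC(=O)c1csc(C#C)n1`, in this assay gives 2100 nM.

Compound 2 therefore stands at a limit of this assay, with no number of its own; it sits at the limit of > 40000 nM in this assay, at which 2 of the 3 values shown sit. Going by the values given here, compound 3 is the only one of the three with a number, and it is built on a different core, so it offers no step to compound 2.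

The compound not yet measured is compound 4, `Brc1nc2ccccc2[se]1`. It differs from compound 2 in one place: bromo in place of hydrogen on an aromatic carbon.

Among the compounds with values here, only one measured step touches this same carbon: a step that the two limits leave unreadable from compound 1 to compound 2. Both ends of that step are limits, so it gives no size. It runs from iodo to hydrogen; the change to compound 4 runs the other way, putting bromo on that carbon. Within the data shown here, the one comparison available shows that a compound with iodo there also stopped at the limit of > 40000 nM in this assay, at which 2 of the 3 values shown sit.

Compound 4 is therefore expected to stay at or near the limit, so the step that the limit leaves unreadable from compound 2 to compound 4 is expected to be small. Compound 4 is estimated at 60000 nM, within 15000 nM to 250000 nM, and most likely reported only as a limit.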

Compound 4, half-maximal inhibitory concentration: > 40000 nM
Compound 4: no number, only a limit; the forecaster's own chance of this, stated with the estimate: 80%; the middle value does not contradict the limit.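

Compound 4 gives > 40000 nM, which is a limit of the assay and not a number, so its steps from compound 1 and from compound 2 cannot be read. From the compounds shown here alone, what stays open is whether hydrogen, iodo and bromo on this aromatic carbon differ at all in this assay; compound 1, compound 2 and compound 4 have no number there.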